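This account rests on a few compounds, and the source may have more. Where it says the series, first, only, none or still open, it means among the compounds named here.

Compound 1, `Cc1nc2cc(C(=O)NCc3ccc(F)cc3O)nn2c(-c2cc(F)c3c(c2C)CCCO3)c1[C@H](OC(C)(C)C)C(=O)O`, gives > 40000 nM in an ADME assay on MT2 cells (Homo sapiens) for cytotoxicity; a lower number here means that less compound is tolerated, a higher number that more compound is tolerated; this value is a limit of the assay.
Compound 2, `Cc1nc2cc(C(=O)NCc3ccc(F)cc3-n3cncn3)nn2c(-c2cc(F)c3c(c2C)CCCO3)c1[C@H](OC(C)(C)C)C(=O)O`, gives > 40000 nM in this assay; this value is a limit of the assay.
Compound 3, `Cc1nc2cc(C(=O)NCCC(C)(C)C)nn2c(-c2cc(F)c3c(c2C)CCCO3)c1[C@H](OC(C)(C)C)C(=O)O`, gives > 40000 nM in this assay; this value is a limit of the assay.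

Compound 3 therefore stands at the same limit as the other two measured compounds, since (the limit of > 40000 nM in this assay, at which 3 of the 3 values shown sit). The three measured steps, a step that the two limits leave unreadable from compound 1 to compound 2, a step that the two limits leave unreadable from compound 1 to compound 3 and a step that the two limits leave unreadable from compound 2 to compound 3, are all left unreadable by these limits, so none of them gives a size that can be carried over.

The unmeasured compound 4 is `Cc1nc2cc(C(=O)NCCC3CCOCC3)nn2c(-c2cc(F)c3c(c2C)CCCO3)c1[C@H](OC(C)(C)C)C(=O)O`. It differs from compound 3 in one place: oxan-4-yl in place of tert-butyl on a saturated chain carbon, two bonds along the chain from an amide-type nitrogen. Within the data shown here, no measured step touches this change, and the only evidence available is that every measured compound sits at the limit. The author therefore expects compound 4 to remain at that limit as well, with no step beyond the scatter, so that the expected step is a step that the limit leaves unreadable from compound 3 to compound 4. Compound 4 is estimated at 60000 nM, within a range from 30000 nM to 150000 nM.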

Compound 4, half-maximal cytotoxic concentration: > 40000 nM
Compound 4 was reported as a limit (the forecaster's own chance of this, stated with the estimate: 85%); the middle value does not contradict the limit.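

No step from compound 1, compound 2 or compound 3 to compound 4 can be read in this assay, since all four compounds sit at one limit: the limit of > 40000 nM in this assay, at which 4 of the 4 values shown sit.

The compounds shown leave open whether these four differ at all in this assay, and at what concentration any of them would become cytotoxic.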